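Growth inhibition notes: from compound 3 to compound 4

The source may hold more compounds than are shown below. What is called first, only, known or untested is meant among the compounds shown, and "the series" means these compounds.

Measured in a functional assay on Jurkat cells (Homo sapiens) for inhibition, read by CCK-8 assay, with a stated time of 48 h; a higher number here means a weaker inhibitor of growth, a lower number a stronger inhibitor of growth:
- compound 1 `Cc1ccccc1Nc1nc(Nc2ccccn2)ncc1Cl`: 20100 nM
- compound 2 `Cc1ccccc1Nc1nc(Nc2ccc(N3CCCCC3)cc2)ncc1Cl`: > 100000 nM, a limit of the assay and not a number
- compound 3 `COc1ccc(CNc2nc(Nc3ccc(N4CCN(C)CC4)cn3)ncc2Cl)cc1`: 12900 nM

Compound 3 at 12900 nM stands within the scatter of compound 1 at 20100 nM. Among the measured compounds shown here, these are the only two actual numbers.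

Compound 4 `CC(C)c1cccc(Nc2nc(Nc3ccc(N4CCN(C)CC4)cn3)ncc2Cl)c1` carries 3-isopropylphenyl in place of 4-methoxybenzyl on a nitrogen on an aromatic ring. For the measured compounds named here, no pair of measured compounds differs in one place only, so the expectation starts from compound 3 at 12900 nM. The estimated change, a 1.3-fold lower number from compound 3 to compound 4 (0.11 log units; within the scatter), is not expected to go beyond the scatter in either direction. For compound 4 the estimated value is 10000 nM, with an expected range of 2000 nM to 40000 nM.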

Compound 4, concentration for 50% growth inhibition: 12300 nM
Estimate against measurement, compound 4: 1.2-fold (0.09 log units) below; measured number inside the range.
By their numbers in this assay, from the lowest: compounds 4, 3 and 1 (each within the scatter of the next). At a limit, above all of these: compound 2.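

In this assay, 3-isopropylphenyl in place of 4-methoxybenzyl gives a 1.0-fold lower number from compound 3 to compound 4 (0.02 log units; within the scatter), and this is the only pair shown that differs in one place. The hydrogen-bond acceptor counted in 4-methoxybenzyl leaves, and the heavy-atom count stays the same, with no reading beyond the scatter at this nitrogen. Nothing measured here bears on a cause for this result.

On these data alone, whether an amine, a carboxylic acid or a longer chain in place of these groups on this nitrogen would move the number beyond the scatter remains open.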